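The source may hold more compounds than are shown below. What is called first, only, known or untested is meant among the compounds shown, and "the series" means these compounds.

Series under study in an ADME assay on a cell-free system (plasma, Homo sapiens) for metabolic stability, with Plasma (Rattus norvegicus) as the target, read by HPLC, at pH 7.4; a lower number here means that the compound disappears faster, a higher number that the compound lasts longer:

compound 1 `CC(=O)Oc1ccccc1C(=O)O[C@H]1CO[C@H]2[C@@H]1OC[C@H]2OC(=O)c1snnc1C` — 0.0065 h
compound 2 `CC(=O)Oc1ccccc1C(=O)O[C@H]1CO[C@H]2[C@@H]1OC[C@H]2OC(=O)c1ccc(O)cc1` — 0.0198 h
compound 3 `CC(=O)Oc1ccccc1C(=O)O[C@H]1CO[C@H]2[C@@H]1OC[C@H]2OC(=O)c1ccccc1` — 0.0107 h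

Compound 1 has the lowest number of the three in this assay; compound 3 sits nearest to it, and compound 2 furthest. Compound 4 `COc1ccc(C(=O)O[C@@H]2CO[C@H]3[C@@H]2OC[C@@H]3OC(=O)c2ccccc2OC(C)=O)cc1` is the next member to be measured; relative to compound 1 it carries 4-methoxyphenyl in place of 4-methyl-1,2,3-thiadiazol-5-yl on a carbonyl carbon.

Going by the values given here, two measured steps bear on this change, both replacing the same group on the carbonyl carbon by a six-membered carbon ring: a 1.6-fold higher number from compound 1 to compound 3 (0.22 log units; within the scatter) and a 3.0-fold higher number from compound 1 to compound 2 (0.48 log units; beyond the scatter). The aryl variant with an oxygen substituent gave the larger gain, so a modest rise is expected for compound 4, roughly a 2.0-fold higher number from compound 1 to compound 4 (0.30 log units; within the scatter). The estimate for compound 4 in this assay is 0.013 h, within 0.006 h to 0.03 h.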

Compound 4, half-life: 0.0183 h
Estimate against measurement, compound 4: 1.4-fold (0.15 log units) below; low and high end bracket the measured number.
By their numbers in this assay, from the lowest: compounds 1, 3, 4 and 2 (each within the scatter of the next, the first and the last beyond it).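

In this assay 4-methoxyphenyl on a carbonyl carbon clears the scatter against 4-methyl-1,2,3-thiadiazol-5-yl, giving a 2.8-fold higher number from compound 1 to compound 4 (0.45 log units; beyond the scatter) as its step. Among the six-membered aromatic rings, added methoxy gives a 1.7-fold higher number from compound 3 to compound 4 (0.23 log units; within the scatter) and methyl on the hydroxy oxygen gives a 1.1-fold lower number from compound 2 to compound 4 (0.03 log units; within the scatter) so neither change separates from the scatter, and a free hydroxy is not required to clear it. Going by these compounds, whether an amine or a carboxylic acid on the aromatic ring, or a longer chain in place of that methyl, would read the same stays open. No measurement here accounts for these steps.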